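Chloro to hydroxy in a set of very weak inhibitors

This account rests on a few compounds, and the source may have more. Where it says the series, first, only, none or still open, it means among the compounds named here.

Measured so far in an assay on cells for inhibition of S-adenosylmethionine decarboxylase proenzyme (Homo sapiens), read by mass spectrometry, at pH 7.2; on this read-out higher numbers stand for weaker inhibition and lower numbers for stronger inhibition:
compound 1 `Nc1nccc(Nc2cc(Cl)cc(Cl)c2)n1` gives > 180000 nM
compound 2 `Nc1ccnc(Nc2cc(Cl)cc(Cl)c2)c1` gives > 180000 nM
compound 3 `Cc1cc(Nc2cc(Cl)c(Cl)c(Cl)c2)nc(N)n1` gives > 63000 nM

Each of these readings is a limit of the assay rather than a measured number. Compound 3 stands at the limit (the limit of > 63000 nM in this assay, at which 1 of the 3 values shown sits). Compound 1 and compound 2 stand at the limit (the limit of > 180000 nM in this assay, at which 2 of the 3 values shown sit). Within this set, then, no compound has a numbered potency, and no step between measured compounds can be drawn, so no size of change is known for any structural edit.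

Compound 4 `Cc1cc(Nc2cc(Cl)c(O)c(Cl)c2)nc(N)n1` has not yet been measured. It differs from compound 3 in one place: hydroxy in place of chloro on an aromatic carbon. Within the data shown here, with no measured step to lean on, the expectation in this assay is no change beyond the usual scatter, in either direction, and a fair chance that the assay again reports only a limit. For compound 4 the estimated value in this assay is 100000 nM, within a range from 30000 nM to 300000 nM. The expected step is a step that the limit leaves unreadable from compound 3 to compound 4.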

Compound 4, half-maximal inhibitory concentration: > 180000 nM
Compound 4: no number, only a limit; the forecaster's own chance of this, stated with the estimate: 70%; middle value at least 1.8-fold (0.25 log units) from the limit.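

Compound 3 and compound 4 each give only a limit of the assay, so the step between them cannot be read in this assay. What potency any of these compounds has, and how hydroxy compares with chloro at this place, remains open.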